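Sec-butyl in place of methyl: compound 3 to compound 4

This account rests on a few compounds, and the source may have more. Where it says the series, first, only, none or still open, it means among the compounds named here.

In a functional assay on HeLa cells (Homo sapiens) for antiproliferative activity, read by MTT assay, with a stated time of 48 h (on this read-out lower numbers stand for stronger inhibition and higher numbers for weaker inhibition), compound 3 (`COC(=O)[C@H](C)NC(=O)c1ccc(Oc2nc3ccccc3nc2NC(C)(C)C)cc1`) gives 55200 nM and compound 1 (`CCCCCCCCCCCCNc1nc2ccccc2nc1Oc1ccc(C(=O)N[C@H](C(=O)OC)[C@H](C)CC)cc1`) gives 40300 nM within the scatter of each other. Compound 2 (`COC(=O)CNC(=O)c1ccc(Oc2nc3ccccc3nc2NC(C)(C)C)cc1`) gives > 50000 nM as a limit of the assay, not a number. Compound 4 (`CC[C@@H](C)[C@H](NC(=O)c1ccc(Oc2nc3ccccc3nc2NC(C)(C)C)cc1)C(=O)OC`) carries sec-butyl in place of methyl on a saturated chain carbon bound to an amide-type nitrogen and a carbonyl carbon. Going by the values given here, the only measured step at that carbon is a step that the limit leaves unreadable from compound 2 to compound 3 and offers no size to carry over. Compound 1 also bears sec-butyl there but differs elsewhere. With compound 1 at 40300 nM no step beyond the scatter is expected in this assay from this change. The expected step reads (a 1.2-fold lower number from compound 3 to compound 4 (0.09 log units; within the scatter)). For compound 4 the estimate is 45000 nM with 20000 nM to 90000 nM as the expected range.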

Compound 4, half-maximal inhibitory concentration: 31900 nM
The estimate for compound 4 lay 1.4-fold (0.15 log units) above the measured number; low and high end bracket the measured number.
By their numbers in this assay, from the lowest: compounds 4, 1 and 3 (each within the scatter of the next).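

In this assay, going by these compounds alone, the first readable step at the saturated chain carbon bound to an amide-type nitrogen and a carbonyl carbon stays within the scatter, with sec-butyl in place of methyl (a 1.7-fold lower number from compound 3 to compound 4 (0.24 log units; within the scatter)). With sec-butyl held at that carbon, tert-butyl in place of dodecyl on the nitrogen on an aromatic ring also stays within the scatter (a 1.3-fold lower number from compound 1 to compound 4 (0.10 log units; within the scatter)). Against hydrogen only a floor can be read (an at least 1.5-fold lower number from compound 2 to compound 4 (0.19 log units; that floor lies within the scatter)), and compound 2 remains a limit of the assay: the limit of > 50000 nM in this assay, at which 1 of the 4 values shown sits.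

On these data alone, whether a carboxylic acid in place of the methyl ester would leave these values unchanged stays open. The same holds for a hexyl chain or a primary amine on that aromatic ring.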